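A few compounds are considered here, and "the series" means these few. Any claim that something is new, unique, unknown or untested is made for them only; others in the source may bear on it.

Compounds measured so far:
compound 1, `CCCCOc1ccc(/C=C2\CCCN=C2c2cccnc2)cc1`, giving 1960 nM in an assay on membranes from brain for displacement of a labelled ligand from Neuronal acetylcholine receptor; alpha4/beta2 (Rattus norvegicus), with a stated time of 3 h; a higher number here means a weaker inhibitor, a lower number a stronger inhibitor
compound 2, `COc1ccc(/C=C2\CCCN=C2c2cccnc2)cc1`, giving 490 nM in this assay

Compound 2 has the lower of the two numbers, and the gap to compound 1 lies beyond the scatter, so on the numbers shown compound 2 is the stronger binder of the pair. Among the measured compounds shown here, the only measured step is a 4.0-fold lower number from compound 1 to compound 2 (0.60 log units; beyond the scatter); it shows that removing carbon from the chain on the oxygen on the aromatic ring made the binding tighter by a modest amount.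

Compound 3, `CC(C)(C)C(=O)Oc1ccc(/C=C2\CCCN=C2c2cccnc2)cc1`, is not yet measured. It differs from compound 2 as follows: (tert-butyl)carbonyl in place of methyl on an oxygen on an aromatic ring. For the measured compounds named here, this change sits on the same oxygen as the one measured step, but runs the other way: a group with more atoms enters instead of leaving. Taking the measured step as the only guide, a larger group there is expected to weaken binding by a step of similar or somewhat greater size, giving in this assay a rise of about a 4.1-fold higher number from compound 2 to compound 3 (0.61 log units; beyond the scatter). Compound 3 is therefore estimated at 2000 nM, with a likely range from 600 nM to 7000 nM.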

Compound 3, inhibition constant: 830 nM
Compound 3: the middle estimate sits 2.4-fold (0.38 log units) above what was measured; low and high end bracket the measured number.
By their numbers in this assay, from the lowest: compounds 2 and 3 (each within the scatter of the next); then compound 1.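

In this assay, (tert-butyl)carbonyl in place of methyl on the oxygen on the aromatic ring gives a 1.7-fold higher number from compound 2 to compound 3 (0.23 log units; within the scatter), so compound 2 and compound 3 cannot be told apart even though the entering group has 6 heavy atoms and the leaving group has 1. The earlier step from compound 1 to compound 2 could have suggested that any larger group on this oxygen costs binding, but compound 3 shows that this does not hold: (tert-butyl)carbonyl in place of butyl gives a 2.4-fold lower number from compound 1 to compound 3 (0.37 log units; beyond the scatter), a modest gain that lies beyond the scatter, so what matters here is the kind of group and not simply that it is larger than methyl. No measurement shown here explains why butyl and (tert-butyl)carbonyl behave differently on this oxygen.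

On these data alone, it remains open whether a smaller acetyl group, a plain hydrogen giving a free hydroxyl, or a longer chain on this oxygen would group with compound 2 and compound 3 or with compound 1. These three compounds also say nothing about changes elsewhere on the shared core, such as a fluorine or an amine placed on it.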